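The source may report more compounds than this note shows. Statements on the series, on what has been measured and on what is new or still open speak of the compounds shown alone.

Measured compounds in a functional assay on MDA-MB-231 cells (Homo sapiens) for cytotoxicity, read by MTT assay, with a stated time of 24 h; a lower number here means a stronger inhibitor, a higher number a weaker inhibitor:
compound 1 `CCCCCCCC(=O)Nc1nnc(S[C@@H]2O[C@H](CO)[C@H](O)[C@H](O)[C@H]2O)s1` — 30800 nM
compound 2 `CCCCCCCCCC(=O)Nc1nnc(S[C@@H]2O[C@H](COC(C)=O)[C@H](OC(C)=O)[C@H](OC(C)=O)[C@H]2OC(C)=O)s1` — 19200 nM
compound 3 `CCCCCCCC/C=C\CCCCCCCCCCCC(=O)Nc1nnc(S[C@@H]2O[C@H](CO)[C@H](O)[C@H](O)[C@H]2O)s1` — 70400 nM

Compound 2 carries the lowest number of the three. Its gap to compound 1 lies within the scatter, so no order between compound 2 and compound 1 can be read from these values. Compound 3 stands apart: its number is higher than that of compound 2 by a margin beyond the scatter, and it is also the compound with the longest chain and the unprotected sugar. For the measured compounds named here, no pair among the measured compounds differs in a single place, so no single step can be attributed to any one structural change.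

Compound 4 `C=CCCCCCCCCC(=O)Nc1nnc(S[C@@H]2O[C@H](COC(C)=O)[C@H](OC(C)=O)[C@H](OC(C)=O)[C@H]2OC(C)=O)s1` is yet to be measured in this assay. It differs from compound 2 as follows: vinyl in place of methyl on a saturated chain carbon, eight bonds along the chain from a carbonyl carbon. The change is small, touches nothing of the sugar or the core, and adds only one double bond outside aromatic rings. The expected step from compound 2 to compound 4 is a 1.1-fold higher number from compound 2 to compound 4 (0.06 log units; within the scatter), that is, none beyond the scatter, with a slight lean toward a higher number. Compound 4 is therefore estimated at 22000 nM, in the range 9000 nM to 55000 nM.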

Compound 4, half-maximal inhibitory concentration: 60900 nM
Beside the measured number, compound 4's estimate is 2.8-fold (0.44 log units) below it, and the stated range ends below it.
By their numbers in this assay, from the lowest: compounds 2, 1, 4 and 3 (each within the scatter of the next, the first and the last beyond it).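

In this assay, for the compounds shown here, vinyl in place of methyl on a saturated chain carbon, eight bonds along the chain from a carbonyl carbon, gives a 3.2-fold higher number from compound 2 to compound 4 (0.50 log units; beyond the scatter) and is the first change that can be read at a single place. A change that leaves the acetylated sugar and the shared core untouched is therefore enough to move the number beyond the scatter, so this part of the chain is not silent in this assay. No measured evidence bears on the reason for this step.

Ethyl at the same place would separate the effect of the double bond from that of the added carbon. Also open, on these data alone, are whether the step carries over to the unprotected sugar and how an amine or a carboxylic acid on the same chain carbon would read.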